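A few compounds are considered here, and "the series" means these few. Any claim that something is new, unique, unknown or untested is made for them only; others in the source may bear on it.

Among the compounds with values here, in a functional assay on aorta (Rattus norvegicus, strain Sprague-Dawley) (a higher number here means that more compound is needed for the effect, a lower number that less compound is needed), compound 1 `Cc1ccccc1COc1nc2c(cc1-c1nc(N)cc(N)n1)c(C)nn2-c1ccccc1` gives 290 nM, the lowest of the three numbers so far. Compound 2 `CC(=O)Nc1c(N)nc(-c2cc3c(C)nn(-c4ccccc4)c3nc2OCc2ccccc2F)nc1N` gives 930 nM, and compound 3 `Cc1nn(-c2ccccc2)c2nc(OCc3ccccc3F)c(-c3nc(N)c4c(n3)[nH]c(=O)n4C)cc12` gives 4900 nM.

Compound 4 `Cc1nn(-c2ccccc2)c2nc(OCc3cccc(F)c3)c(-c3nc(N)cc(N)n3)cc12` differs from compound 1 by one change: 3-fluorophenyl in place of 2-methylphenyl on a saturated chain carbon bound to an oxygen on an aromatic ring. In words, 3-fluorophenyl stands in place of 2-methylphenyl on a saturated chain carbon bound to an oxygen on an aromatic ring.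

Within the data shown here, only one measured step is available, a 5.3-fold higher number from compound 2 to compound 3 (0.72 log units; beyond the scatter). It is modest but beyond the scatter, and it exchanges a group on an aromatic carbon, so it does not test the change at hand. Among the measured compounds shown here, the series therefore holds no measured step at this place, and the size and direction of any effect in this assay remain open. No shift beyond the scatter is expected, with a slight lean towards a higher number, and the estimated step is a 1.4-fold higher number from compound 1 to compound 4 (0.14 log units; within the scatter). The expected value for compound 4 is 400 nM, within an estimated range of 120 nM to 1300 nM.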

Compound 4, half-maximal effective concentration: 360 nM
Estimate against measurement, compound 4: 1.1-fold (0.05 log units) above; measured number inside the range.
By their numbers in this assay, from the lowest: compounds 1 and 4 (each within the scatter of the next); then compound 2; then compound 3.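

In this assay, within the data shown here, the step is a 1.2-fold higher number from compound 1 to compound 4 (0.09 log units; within the scatter) and gives the first measured reading at this place: 3-fluorophenyl in place of 2-methylphenyl on a saturated chain carbon bound to an oxygen on an aromatic ring leaves compound 1 and compound 4 indistinguishable. With the rest of the molecule the same, this place accepts either of these two groups without a shift beyond the scatter. The data on hand offer no explanation for this outcome.

The exchange alters both the substituent and its place on the ring, so this one step cannot separate the two. Still open, as far as these compounds go, is whether the number would hold with an amine or a carboxylic acid on that ring, or with a longer chain in place of the benzyl link.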